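The compounds below may be only part of what the source reports. "The series", "measured", "known", "first", "only" and "open" are said of these compounds alone.

Measured so far:
compound 1 `Cc1cc(N2CC[C@@H](C)[C@@H](N(C)c3ncnc4[nH]ccc34)C2)n2nc(SCc3ccc(C(F)(F)F)cc3)nc2n1` — 9540 nM
compound 2 `CCc1cc(N2CC[C@@H](C)[C@@H](N(C)c3ncnc4[nH]ccc34)C2)n2ncnc2n1` — > 100000 nM

Of the compounds shown here, two have been tested in a functional assay on HGC-27 cells (Homo sapiens) for inhibition, read by MTT assay, with a stated time of 72 h; on this read-out lower numbers stand for stronger inhibition and higher numbers for weaker inhibition. Among the measured compounds shown here, compound 1 gives 9540 nM in this assay and is the only compound with a number. Compound 2 gives only a limit in this assay, reported as > 100000 nM, which is a limit and not a number; this is the one shown in the limit of > 100000 nM in this assay, at which 1 of the 2 values shown sits. Compound 1 therefore stands alone as the single measured point, with nothing to set beside it but that limit.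

Compound 3 `Cc1cc(N2CC[C@@H](C)[C@@H](N(C)c3ncnc4[nH]ccc34)C2)n2nc(SCc3nc4ccccc4[nH]3)nc2n1` has not yet been measured. It keeps the shared core of compound 1 and changes one group: 1H-benzimidazol-2-yl in place of 4-(trifluoromethyl)phenyl on a saturated chain carbon bound to a sulfur. For the measured compounds named here, no two measured compounds differ in one place only, so there is no measured step to say how large such a change tends to be here. The change is expected to be modest, a 1.2-fold lower number from compound 1 to compound 3 (0.08 log units; within the scatter), and could fall in either direction, most likely close to the scatter. In this assay compound 3 is expected to give about 8000 nM, with a range from 2000 nM to 40000 nM.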

Compound 3, half-maximal inhibitory concentration: > 100000 nM
Compound 3: a limit, no number; the forecaster's own chance of this, stated with the estimate: 15%; middle value at least 12-fold (1.09 log units) away from the limit.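

Placing 1H-benzimidazol-2-yl in place of 4-(trifluoromethyl)phenyl on a saturated chain carbon bound to a sulfur gives, in this assay, an at least 10-fold higher number from compound 1 to compound 3 (1.02 log units; beyond the scatter), so the read-out is sensitive to the group carried at this position. Compound 3 gives only a limit, > 100000 nM, which is not a number, so the step is a minimum and its true size cannot be read: the limit of > 100000 nM in this assay, at which 2 of the 3 values shown sit. With the shared core unchanged, this single pair shows that the core alone does not secure a measurable value in this assay, and that of these two groups only 4-(trifluoromethyl)phenyl gives one.

One pair cannot separate the possible sources of the step, which could lie in the added five-membered ring, in the loss of the trifluoromethyl group, or in both. Going by these compounds, it remains open whether a plain phenyl, a pyridine ring or a longer chain between the sulfur and the ring would give a number in this assay, and whether any group at this position would give a lower number than compound 1 does.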